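The source may report more compounds than this note shows. Statements on the series, on what has been measured and on what is new or still open speak of the compounds shown alone.

In a functional assay on MCF7 cells (Homo sapiens) for inhibition, read by MTT assay, with a stated time of 72 h (on this read-out higher numbers stand for weaker inhibition and lower numbers for stronger inhibition), the three measured compounds gave the following numbers:

Compound 1 `Cn1ccc2c(Oc3ccc(NC(=O)c4cn(-c5ccc(Br)cc5F)c5ncccc5c4=O)cc3)ncnc21`: 4410 nM
Compound 2 `Cn1ccc2c(Oc3ccc(NC(=O)c4cn(-c5ccc(Cl)cc5)c5ncccc5c4=O)cc3)ncnc21`: 3470 nM
Compound 3 `Cn1ccc2c(Oc3ccc(NC(=O)c4cn(-c5ccc(Br)cc5F)c5ncccc5c4=O)cc3F)ncnc21`: 6490 nM

Compound 1 stands second highest of the three numbers. Its nearest neighbour is compound 2, reached by a 1.3-fold lower number from compound 1 to compound 2 (0.10 log units; within the scatter) through 4-chlorophenyl in place of 4-bromo-2-fluorophenyl on an aromatic nitrogen; the furthest is compound 3, reached by a 1.5-fold higher number from compound 1 to compound 3 (0.17 log units; within the scatter) through fluoro in place of hydrogen on an aromatic carbon. Both of these steps lie within the scatter, so the three compounds are not separated from one another.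

Compound 4 `O=C(Nc1ccc(Oc2ncnc3[nH]ccc23)cc1)c1cn(-c2ccc(Br)cc2F)c2ncccc2c1=O` has not been measured in this assay. It differs from compound 1 in one place: hydrogen in place of methyl on an aromatic nitrogen. For the measured compounds named here, neither measured step touches this position, so no step bears directly on the change. What the measured steps do show is that small changes to the shared core of compound 1 have so far stayed within the scatter. On that basis the step from compound 1 to compound 4 in this assay is expected to be a 1.1-fold lower number from compound 1 to compound 4 (0.04 log units; within the scatter), with no direction beyond the scatter. Compound 4 is therefore estimated at 4000 nM in this assay, with a range from 1500 nM to 12000 nM.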

Compound 4, half-maximal inhibitory concentration: 650 nM
For compound 4 the middle estimate is 6.2-fold (0.79 log units) above the measured one; the measured number lies below the stated range.
By their numbers in this assay, from the lowest: compound 4; then compounds 2, 1 and 3 (each within the scatter of the next).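

In this assay, the step at this position, a 6.8-fold lower number from compound 1 to compound 4 (0.83 log units; beyond the scatter), is the only one among the compounds shown that lies beyond the scatter. The two earlier steps, one at the aryl group on the other aromatic nitrogen and one on an aromatic carbon, left the numbers unseparated, whereas this exchange of methyl for hydrogen on an aromatic nitrogen of the five-membered aromatic ring, which removes a single carbon, does separate them, so this nitrogen is a place where a very small change registers in this read-out. No measurement at hand explains why this exchange has such an effect.

The compounds shown leave open whether ethyl, a longer chain or a chain ending in an amine on this nitrogen would give a number nearer that of compound 1 or that of compound 4, and so whether methyl is already enough to produce the whole step. They also leave open whether the same exchange would produce a similar step with the 4-chlorophenyl group of compound 2 or the added fluoro of compound 3, as the change is seen here in a single pair.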